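Bromine Added to the Methyl Analogue: Compound 4 Expected

A few compounds are considered here, and "the series" means these few. Any claim that something is new, unique, unknown or untested is made for them only; others in the source may bear on it.

Compound 3 `COC(=O)[C@@]1(C)CCC=C2[C@@H]1CC[C@@H](C)[C@]2(C)Cc1c(C)[nH]c2ccccc12` belongs to a small set built on one shared core. In a functional assay on A549 cells (Homo sapiens) for inhibition, read by sulforhodamine B assay, with a stated time of 48 h (on this read-out lower numbers stand for stronger inhibition of growth and higher numbers for weaker inhibition of growth), compound 3 gives 15000 nM; compound 2 `COC(=O)[C@@]1(C)CCC=C2[C@@H]1CC[C@@H](C)[C@]2(C)Cc1c[nH]c2ccc(Br)cc12` gives 15000 nM, the same number at the digits shown, and together these two are the highest of the three. Compound 1 `COC(=O)[C@@]1(C)CCC=C2[C@@H]1CC[C@@H](C)[C@]2(C)Cc1c[nH]c2ccccc12` gives 5000 nM. The step of a 3.0-fold higher number from compound 1 to compound 3 (0.48 log units; beyond the scatter) came from a methyl in place of hydrogen on an aromatic carbon, and the step of a 3.0-fold higher number from compound 1 to compound 2 (0.48 log units; beyond the scatter) came from the very change now applied to compound 3. Compound 4 `COC(=O)[C@@]1(C)CCC=C2[C@@H]1CC[C@@H](C)[C@]2(C)Cc1c(C)[nH]c2ccc(Br)cc12` differs from compound 3 by bromo in place of hydrogen on an aromatic carbon. Because the step of a 3.0-fold higher number from compound 1 to compound 2 (0.48 log units; beyond the scatter) weakened growth inhibition, a step of similar size is expected here. For compound 4 the expected step is a 3.0-fold higher number from compound 3 to compound 4 (0.48 log units; beyond the scatter). Compound 4 is estimated at 45000 nM, within 15000 nM to 130000 nM.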

Compound 4, concentration for 50% growth inhibition: 15000 nM
Beside the measured number, compound 4's estimate is 3.0-fold (0.48 log units) above it, and the stated range covers the measured number.
By their numbers in this assay, from the lowest: compound 1; then compounds 2, 3 and 4 (each within the scatter of the next).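

Bromo in place of hydrogen gives no change at the digits printed from compound 3 to compound 4 (within the scatter), so the step it produced without the methyl does not repeat with the methyl present: the same change on two cores in this assay, a 3.0-fold higher number (0.48 log units; beyond the scatter) from compound 1 to compound 2 and no change at the digits printed (within the scatter) from compound 3 to compound 4, 3.0-fold (0.48 log units) apart, beyond the scatter of two such steps Methyl in place of hydrogen likewise gives no change at the digits printed from compound 2 to compound 4 (within the scatter), so in this assay the two changes do not add up: the same change on two cores in this assay, a 3.0-fold higher number (0.48 log units; beyond the scatter) from compound 1 to compound 3 and no change at the digits printed (within the scatter) from compound 2 to compound 4, 3.0-fold (0.48 log units) apart, beyond the scatter of two such steps Once either group is present, the other leaves the number unchanged at the digits printed.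

Going by these compounds, whether an amine or a carboxylic acid in the bromo's place would also leave the number unchanged remains open. So does the outcome with a longer chain in place of the methyl.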